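This account rests on a few compounds, and the source may have more. Where it says the series, first, only, none or still open, it means among the compounds named here.

Measured compounds, with their values in a functional assay on U-87MG ATCC cells (Homo sapiens) for antiproliferative activity, read by MTT assay, with a stated time of 48 h; on this read-out higher numbers stand for weaker inhibition and lower numbers for stronger inhibition:

Compound 1, `O=C(/C=C\Nc1ccc(C(F)(F)F)cc1)c1cn(-c2ccccc2)nc1-c1ccccc1`: > 50000 nM, which is a limit of the assay and not a number.
Compound 2, `O=C(/C=C\Nc1ccc(O)cc1)c1cn(-c2ccccc2)nc1-c1ccccc1`: 4290 nM.
Compound 3, `O=C(/C=C\Nc1ccc(C(F)(F)F)cc1)c1cn(-c2ccccc2)nc1-c1ccc(F)cc1`: > 50000 nM, again a limit of the assay rather than a number.

Compound 1 and compound 2 share one core and differ only in one group: hydroxy in place of trifluoromethyl on an aromatic carbon. This change gives an at least 11-fold lower number from compound 1 to compound 2 (1.06 log units; beyond the scatter). Since the value of compound 1 is a limit, only the lower bound of that step can be read, and this rests on (the limit of > 50000 nM in this assay, at which 2 of the 3 values shown sit).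

Compound 3 differs from compound 1 in its core: fluoro in place of hydrogen on an aromatic carbon. The step is a step that the two limits leave unreadable from compound 1 to compound 3, because both values sit at the limit of > 50000 nM in this assay, at which 2 of the 3 values shown sit.

Compound 4, `O=C(/C=C\Nc1ccc(O)cc1)c1cn(-c2ccccc2)nc1-c1ccc(F)cc1`, has not been measured in this assay. It stands to compound 3 as compound 2 stands to compound 1: hydroxy in place of trifluoromethyl on an aromatic carbon. The place is described in the same words in both cases, so this is the same change, made once more on the core that carries the fluoro group. Among the compounds with values here, the only guide is the step from compound 1 to compound 2, which is an at-least statement because the value of compound 1 is a limit. Compound 4 is therefore expected to show an at least 10-fold lower number from compound 3 to compound 4 (1.00 log units; beyond the scatter), a step of the same kind as an at least 11-fold lower number from compound 1 to compound 2 (1.06 log units; beyond the scatter). Taking the value of compound 2, 4290 nM, as the nearest measured anchor, compound 4 is estimated at 5000 nM, with a range from 1500 nM to 30000 nM.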

Compound 4, half-maximal inhibitory concentration: 4700 nM
Beside the measured number, compound 4's estimate is 1.1-fold (0.03 log units) above it; the range from low to high includes it.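

In this assay, hydroxy in place of trifluoromethyl again gives a large step on the core that carries the fluoro group, an at least 10-fold lower number from compound 3 to compound 4 (1.02 log units; beyond the scatter), so the change carries over from one core to the other in direction, and the two steps can be set side by side: the same change on two cores in this assay, an at least 11-fold lower number (1.06 log units; beyond the scatter) from compound 1 to compound 2 and an at least 10-fold lower number (1.02 log units; beyond the scatter) from compound 3 to compound 4; the limit leaves it open whether they differ

What this does not show is the true size of either step, and the step from compound 1 to compound 3 cannot be read at all, since in both cases the trifluoromethyl compounds give limits of the assay and not numbers: the limit of > 50000 nM in this assay, at which 2 of the 4 values shown sit.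

The fluoro group can be read only on the hydroxy compounds, where a 1.1-fold higher number from compound 2 to compound 4 (0.04 log units; within the scatter) stays within the scatter, so the two cores behave alike there, though two cores are too few to make a rule for the whole series.

The compounds shown hold only two groups at this place, so it remains open whether a methoxy group, an amine or a carboxylic acid there would give a number like that of the hydroxy compounds. Going by these compounds, it also remains open whether the same change would give a step of this kind on a core with chlorine or a methyl group in place of the fluoro group.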